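Thiophene for furan on the shared core: cytotoxicity notes

A few compounds are considered here, and "the series" means these few. Any claim that something is new, unique, unknown or untested is made for them only; others in the source may bear on it.

Compound 1 `O=C(NCc1cccs1)[C@@H]1CN(C(=O)c2cc(=O)[nH]c(=O)[nH]2)CCN1Cc1ccc(Cl)cc1Cl` is assessed in a toxicity assay on Vero C1008 cells (Chlorocebus sabaeus) for cytotoxicity, with a stated time of 26 h (on this read-out lower numbers stand for higher toxicity in this test and higher numbers for lower toxicity in this test), where its value is a limit of the assay: compound 1 gives > 100000 nM. Compound 2 `O=C(NCc1ccco1)[C@@H]1CN(C(=O)c2cc(=O)[nH]c(=O)[nH]2)CCN1c1ccc(Cl)c(Cl)c1` also stands at a limit in this assay: compound 2 gives > 100000 nM. Both values sit at the limit of > 100000 nM in this assay, at which 2 of the 2 values shown sit, so compound 2 shows no measurable toxicity on this read-out. Compound 3 `O=C(NCc1cccs1)[C@@H]1CN(C(=O)c2cc(=O)[nH]c(=O)[nH]2)CCN1c1ccc(Cl)c(Cl)c1` is not yet measured. It differs from compound 2 by thiophen-2-yl in place of furan-2-yl on a saturated chain carbon bound to an amide-type nitrogen. For the measured compounds named here, no measured step exists on which to rest a direction, so no change beyond the scatter is expected. Compound 3 is expected to remain at the limit, estimated at 150000 nM, within 60000 nM to 400000 nM. The expected step that the limit leaves unreadable from compound 2 to compound 3 is none beyond the scatter.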

Compound 3, half-maximal cytotoxic concentration: > 100000 nM
Compound 3 was reported as a limit (the forecaster's own chance of this, stated with the estimate: 85%); the middle value does not contradict the limit.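

Neither the step from compound 2 to compound 3 nor the step from compound 1 to compound 3 can be read in this assay: the limit of > 100000 nM in this assay, at which 3 of the 3 values shown sit.

The compounds shown leave open whether thiophen-2-yl and furan-2-yl differ at all on this read-out, and whether any change to the shared core gives measurable toxicity.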